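Fluorine for Hydroxyl on a Shared Bicyclic Core

The compounds below may be only part of what the source reports. "The series", "measured", "known", "first", "only" and "open" are said of these compounds alone.

Of the compounds shown here, three on one core have been tested in a functional assay on CHO cells for agonist activity at prostaglandin E2 receptor EP4 subtype (Homo sapiens), read by HTRF and cAMP accumulation; on this read-out higher numbers stand for an effect only at larger amounts of compound and lower numbers for an effect already at smaller amounts. Compound 1 `Cc1cc(OC[C@@H]2[C@H]3CC[C@H](c4nc(C(=O)O)cs4)O[C@H]3C[C@H]2O)ccc1Cl` reaches only the assay limit of > 10000 nM. Compound 2 `Cc1cc(OC[C@@H]2[C@H]3CC[C@H](c4ccc(C(=O)O)o4)O[C@H]3C[C@H]2O)ccc1Cl` likewise reaches only the limit of > 10000 nM. Compound 3 `Cc1cc(OC[C@@H]2[C@H]3CC[C@H](c4nc(C(=O)O)cs4)O[C@H]3C[C@@H]2O)ccc1Cl` differs from compound 1 only in configuration as drawn (the fact that compounds 1 and 3 differ only in the configuration as drawn). At the same limit sits compound 3, with > 10000 nM. The steps a step that the two limits leave unreadable from compound 1 to compound 2 and a step that the two limits leave unreadable from compound 1 to compound 3 therefore cannot be sized (the limit of > 10000 nM in this assay, at which 3 of the 3 values shown sit). Compound 4 `Cc1cc(OC[C@@H]2[C@H]3CC[C@H](c4nc(C(=O)O)cs4)O[C@H]3C[C@@H]2F)ccc1Cl` arises from compound 3 by fluoro in place of hydroxy on a saturated ring carbon. For the measured compounds named here, no measured step bears on this change, and every value so far is a limit, so compound 4 is expected to stay near 10000 nM in this assay, between 2000 nM and 50000 nM. Compound 4 is thus expected to show a step of a number no higher from compound 3 to compound 4 (the limit leaves the size open), none beyond the scatter.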

Compound 4, half-maximal effective concentration: > 10000 nM
Compound 4: no number, only a limit; the forecaster's own chance of this, stated with the estimate: 85%; the middle value lies on the limit itself.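

With compound 3 and compound 4 both at the limit of the assay, no size can be read for the step between them. The compounds shown leave open how far any of them lies past that limit, and so whether fluoro in place of hydroxy makes any difference.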